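This account rests on a few compounds, and the source may have more. Where it says the series, first, only, none or still open, it means among the compounds named here.

Compound 1 `COc1ccc(/C=N/NC(=S)NC(C)(C)[C@H]2CC=C(C)CC2)cc1`: 1500 nM
Compound 2 `CC1=CC[C@H](C(C)(C)NC(=S)N/N=C/c2ccccc2O)CC1`: 800 nM
Compound 3 `CC1=CC[C@H](C(C)(C)NC(=S)N/N=C/c2ccc(F)cc2)CC1`: > 100000 nM (a limit of the assay, not a number)

In a functional assay on K562 cells (Homo sapiens) for inhibition, read by sulforhodamine B assay, with a stated time of 48 h (on this read-out higher numbers stand for weaker inhibition of growth and lower numbers for stronger inhibition of growth), compound 1 gives 1500 nM. In this assay compound 2 gives 800 nM; the step of a 1.9-fold lower number from compound 1 to compound 2 (0.27 log units; within the scatter) is small, so the two sit together. Compound 3 stands apart from both: its value > 100000 nM is a limit of the assay and not a number, as marked by the limit of > 100000 nM in this assay, at which 1 of the 3 values shown sits. For the measured compounds named here, the step of an at least 66-fold higher number from compound 1 to compound 3 (1.82 log units; beyond the scatter) and the step of an at least 120-fold higher number from compound 2 to compound 3 (2.09 log units; beyond the scatter) are both large and both run into that limit, so compound 3 is the one member of the series whose growth inhibition is too weak to be quantified here.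

Compound 4 `CC1=CC[C@H](C(C)(C)NC(=S)N/N=C/c2cccc(Cl)c2)CC1` is not yet measured. It differs from compound 3 by 3-chlorophenyl in place of 4-fluorophenyl on a carbon with a double bond to nitrogen. Going by the values given here, no measured step swaps one halogen-bearing ring for another, so neither an at least 66-fold higher number from compound 1 to compound 3 (1.82 log units; beyond the scatter) nor an at least 120-fold higher number from compound 2 to compound 3 (2.09 log units; beyond the scatter) fixes the direction; they show only that compound 3 lies at the limit while compounds 1 and 2 lie well inside the measurable range. Compound 4 is therefore expected to fall between these outcomes, with the estimated step of an at least 5.0-fold lower number from compound 3 to compound 4 (0.69 log units; beyond the scatter) most likely downward but carrying a wide range. The estimate for compound 4 is 20000 nM, in an expected range from 2000 nM to 100000 nM.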

Compound 4, concentration for 50% growth inhibition: 5400 nM
Beside the measured number, compound 4's estimate is 3.7-fold (0.57 log units) above it; measured number inside the range.
By their numbers in this assay, from the lowest: compounds 2 and 1 (each within the scatter of the next); then compound 4. At a limit, above all of these: compound 3.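

In this assay the change of ring gives an at least 18-fold lower number from compound 3 to compound 4 (1.26 log units; beyond the scatter), so a halogen-bearing phenyl ring on a carbon with a double bond to nitrogen does not by itself put a compound at the limit. Going by these compounds, compound 3 is a limit and not a number, so this step has only a lower bound and its true size stays unknown: the limit of > 100000 nM in this assay, at which 1 of the 4 values shown sits. The other two steps, a 6.8-fold higher number from compound 2 to compound 4 (0.83 log units; beyond the scatter) and a 3.6-fold higher number from compound 1 to compound 4 (0.56 log units; beyond the scatter), show that the 3-chlorophenyl ring gives measurable growth inhibition but does not match the oxygen-bearing rings of compounds 1 and 2.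

The change from 4-fluorophenyl to 3-chlorophenyl swaps both the halogen and where it sits on the ring, so the compounds shown cannot tell which of the two carries the step. Also open is how 4-chlorophenyl or 3-fluorophenyl would read at this place, which would separate those two changes, and how a phenyl ring bearing an amine or a carboxylic acid would compare with the rings shown.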